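Fluoro for chloro on the weakly inhibiting compound 1

This account rests on a few compounds, and the source may have more. Where it says the series, first, only, none or still open, it means among the compounds named here.

Going by the values given here, in a functional assay on SMMC-7721 cells (Homo sapiens) for inhibition, read by CCK-8 assay, with a stated time of 72 h, tested at 8 uM (on this read-out higher numbers stand for more inhibition of growth at the one concentration tested and lower numbers for less inhibition of growth), compound 1 (`Nc1ccccc1NC(=O)/C=C/c1ccc(CSc2ccc(Cl)cc2)cc1`) gives 16.5% and holds the lower of the two numbers so far. Compound 2 (`CCc1ccc(SCc2ccc(C(=O)Nc3ccccc3N)cc2)cc1`) gives 82.9% in the same read-out, a gap beyond the scatter. Compound 3 (`Nc1ccccc1NC(=O)/C=C/c1ccc(CSc2ccc(F)cc2)cc1`) differs from compound 1 by fluoro in place of chloro on an aromatic carbon (fluoro in place of chloro on an aromatic carbon, para to a large group). Among the compounds with values here, no measured step covers this change, so no step beyond the scatter is expected in this assay. The expected step is a number 1.5 percentage points higher from compound 1 to compound 3 (within the scatter) and stays small. Compound 3 is estimated at 18% within an expected range of 5% to 38% in this read-out.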

Compound 3, percent growth inhibition at one concentration: 15.4%
Compound 3: middle estimate off by 2.6 percentage points, on the high side, within the range that was stated.
By their numbers in this assay, from the lowest: compounds 3 and 1 (each within the scatter of the next); then compound 2.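

Exchanging 4-chlorophenyl for 4-fluorophenyl gives, in this assay, a number 1.1 percentage points lower from compound 1 to compound 3 (within the scatter), and this read-out does not separate the two halogens at this position. Compound 1 and compound 3 therefore stand level, with inhibition of growth low for both. No measurement on these compounds bears on why this exchange leaves the number within the scatter.

As far as these compounds go, whether an amine, a methoxy group or a longer chain at this position would part from the two halogens stays open. Compound 2 differs from compound 1 in more than one place, so no single change accounts for the gap between them.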